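From bromo to chloro: expectations for compound 4

This account rests on a few compounds, and the source may have more. Where it says the series, first, only, none or still open, it means among the compounds named here.

- compound 1 `Cc1cccc(NS(=O)(=O)c2ccc(N3CCNC3=O)cc2)c1`: 69 nM
- compound 2 `CCc1ccc(NS(=O)(=O)c2ccc(N3CCNC3=O)cc2)cc1`: 480 nM
- compound 3 `O=C1NCCN1c1ccc(S(=O)(=O)Nc2cccc(Br)c2)cc1`: 59 nM

All three values come from a functional assay on M21 cells (Homo sapiens) for antiproliferative activity, read by sulforhodamine B assay, with a stated time of 48 h; on this read-out higher numbers stand for weaker inhibition and lower numbers for stronger inhibition. Compound 3 sits at the low end of these numbers, and it shares that end with compound 1. The data show an 8.1-fold lower number from compound 2 to compound 3 (0.91 log units; beyond the scatter), but only a 1.2-fold lower number from compound 1 to compound 3 (0.07 log units; within the scatter). The next compound is compound 4 `O=C1NCCN1c1ccc(S(=O)(=O)Nc2cccc(Cl)c2)cc1`, which has chloro in place of bromo on an aromatic carbon. Among the compounds with values here, no measured pair makes this exact exchange. The closest guide is the exchange of methyl for bromo, which gave a 1.2-fold lower number from compound 1 to compound 3 (0.07 log units; within the scatter). The larger 7.0-fold higher number from compound 1 to compound 2 (0.84 log units; beyond the scatter) involved a different change of the group on the sulfonamide nitrogen, so it is a weaker guide. The expected change is a 1.1-fold higher number from compound 3 to compound 4 (0.04 log units; within the scatter), so no step beyond the scatter is expected. For compound 4 the estimate is 65 nM, with an expected range of 30 nM to 140 nM.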

Compound 4, half-maximal inhibitory concentration: 25 nM
Estimate against measurement, compound 4: 2.6-fold (0.41 log units) above, and the stated range ends above it.
By their numbers in this assay, from the lowest: compound 4; then compounds 3 and 1 (each within the scatter of the next); then compound 2.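

Methyl and bromo gave numbers within the scatter of each other, so this position looked insensitive to the group placed there, but chloro in place of bromo gives a 2.4-fold lower number from compound 3 to compound 4 (0.37 log units; beyond the scatter) and chloro in place of methyl gives a 2.8-fold lower number from compound 1 to compound 4 (0.44 log units; beyond the scatter) on the same ring carbon. Swapping a single atom here can therefore shift the number beyond the scatter. The 3-chlorophenyl group also widens the gap to the 4-ethylphenyl group, with a 19-fold lower number from compound 2 to compound 4 (1.28 log units; beyond the scatter) in the comparison of those two groups. No measurement available here accounts for the difference between chloro and bromo.

Still open, going by these compounds, is how fluoro, methoxy or an amine would fare at this same place. Also open, on these data alone, is whether chloro would keep its low number elsewhere on the ring.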